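The compounds below may be only part of what the source reports. "The series", "measured", "known", "first", "only" and "open" are said of these compounds alone.

Compound 1 `CCCCCCCCCCCCCCCCCCNC(=O)[C@@H]1CSC(c2ccc(OC)cc2)N1` gives 19000 nM in a functional assay on PC-3 cells (Homo sapiens) for antiproliferative activity, read by sulforhodamine B assay; on this read-out lower numbers stand for stronger inhibition and higher numbers for weaker inhibition.
Compound 2 `CCCCCCCCCCCCCCCCCCNC(=O)[C@@H]1CSC(c2cc(OC)c(OC)c(OC)c2)N1` gives 4000 nM in this assay.
Compound 3 `CCCCCCCCCCCCCCCCCCNC(=O)[C@@H]1CSC(c2ccc(O)cc2)N1` gives 5300 nM in this assay.

Among these three numbers compound 3 stands second highest. Its nearest neighbour is compound 2, separated by a 1.3-fold higher number from compound 2 to compound 3 (0.12 log units; within the scatter); its furthest is compound 1, separated by a 3.6-fold lower number from compound 1 to compound 3 (0.55 log units; beyond the scatter). Compound 4 `CCCCCCCCCCCCCCCCCCNC(=O)[C@@H]1CSC(c2c(OC)cc(OC)cc2OC)N1` carries the change (2,4,6-trimethoxyphenyl in place of 4-hydroxyphenyl on a saturated ring carbon). For the measured compounds named here, two measured steps bear on this: a 4.8-fold lower number from compound 1 to compound 2 (0.68 log units; beyond the scatter), where three methoxy groups entered in place of one, and a 1.3-fold higher number from compound 2 to compound 3 (0.12 log units; within the scatter), where a hydroxyl stood in for them. Going by the values given here, the arrangement of three methoxy groups in compound 4 has no measured counterpart, so only a modest movement is expected. Compound 4 is therefore expected to show a 1.1-fold higher number from compound 3 to compound 4 (0.05 log units; within the scatter) in this assay. The estimate for compound 4 is 6000 nM, with a range from 2000 nM to 20000 nM.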

Compound 4, half-maximal inhibitory concentration: 10600 nM
The estimate for compound 4 lay 1.8-fold (0.25 log units) below the measured number, and the stated range covers the measured number.
By their numbers in this assay, from the lowest: compounds 2, 3, 4 and 1 (each within the scatter of the next, the first and the last beyond it).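

In this assay, the placing of the methoxy groups on the aromatic ring matters: with their count unchanged, 2,4,6-trimethoxyphenyl in place of 3,4,5-trimethoxyphenyl gives a clear step (a 2.7-fold higher number from compound 2 to compound 4 (0.42 log units; beyond the scatter)). Compound 4 also stays within the scatter of the compounds with one oxygen substituent (a 1.8-fold lower number from compound 1 to compound 4 (0.25 log units; within the scatter); a 2.0-fold higher number from compound 3 to compound 4 (0.30 log units; within the scatter)), so three methoxy groups alone do not secure the low number of compound 2. Nothing measured here explains this difference.

Still open, from the compounds shown here alone, is how an amine or a carboxylic acid on the aromatic ring, or a shorter chain on the amide, would fare.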